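Tert-butyl to methyl on the shared core: working notes

The source may report more compounds than this note shows. Statements on the series, on what has been measured and on what is new or still open speak of the compounds shown alone.

Measured so far:
compound 1 `CCc1nnc(O)n2c(C(C)(C)C)nc(C)c12` gives 26000 nM in a functional assay for inhibition, with Homo sapiens as the target; on this read-out lower numbers stand for stronger inhibition and higher numbers for weaker inhibition
compound 2 `Cc1nc(C(C)(C)C)n2c(O)nncc12` gives 31000 nM in this assay

Among the measured compounds shown here, compound 1 stands together with compound 2: the only measured step, hydrogen in place of ethyl on an aromatic carbon, gives a 1.2-fold higher number from compound 1 to compound 2 (0.08 log units; within the scatter), so the two numbers cannot be told apart, and both lie in the weak range of this assay.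

Compound 3 `CCc1nnc(O)n2c(C)nc(C)c12` is not yet measured. From compound 1 it differs by methyl in place of tert-butyl on an aromatic carbon. For the measured compounds named here, no measured step touches this position: the one step in hand, a 1.2-fold higher number from compound 1 to compound 2 (0.08 log units; within the scatter), concerns the ethyl group on another carbon and is itself within the scatter. Going by the values given here, it shows only that the core tolerates a change there without a shift in this assay; it gives no guide to the tert-butyl. For compound 3 the expected step is no change at the digits printed from compound 1 to compound 3 (within the scatter), that is none beyond the scatter, with a wide range to either side because compound 1 at 26000 nM is the only anchor. The estimate for compound 3 in this assay is 26000 nM, with a range from 8000 nM to 90000 nM.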

Compound 3, half-maximal inhibitory concentration: > 48000 nM
Compound 3 gave a limit, no number; the forecaster's own chance of this, stated with the estimate: 15%; middle value at least 1.8-fold (0.26 log units) from the limit.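

In this assay compound 3 gives > 48000 nM, which is a limit of the assay and not a number. Methyl in place of tert-butyl on the aromatic carbon between two ring nitrogen atoms gives an at least 1.8-fold higher number from compound 1 to compound 3 (0.26 log units; that floor lies within the scatter), so the true size of the step is not fixed: the printed floor does not separate it from the scatter, and the real step may be larger. This is the first measured step at this position, and unlike the ethyl-to-hydrogen step on the other carbon, it yields no number, while showing no gain in inhibition from methyl at this position; the reading rests on a single compound at the limit: the limit of > 48000 nM in this assay, at which 1 of the 3 values shown sits.

The compounds shown leave open how far compound 3 lies past its limit, and therefore whether tert-butyl contributes anything real to the weak inhibition of compound 1. They also leave open what an isopropyl group, a phenyl ring or an amine on this same carbon would do in this assay, and whether any group there would bring the series out of the weak range.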